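Benzylamino to anilino, starting from a limit

A few compounds are considered here, and "the series" means these few. Any claim that something is new, unique, unknown or untested is made for them only; others in the source may bear on it.

Compound 1 `COc1cc2nccc(Oc3ccc4c(NC(=O)c5cccc(C(F)(F)F)c5)nn(C)c4c3)c2cc1OC` and compound 2 `COc1cc2nccc(Oc3ccc4c(NCc5ccccc5)nn(C)c4c3)c2cc1OC` share a core and differ in the group on a nitrogen on an aromatic ring. In a functional assay on HUVEC cells (Homo sapiens) for inhibition, with stated times of 2 h and 72 h (a higher number here means a weaker inhibitor, a lower number a stronger inhibitor), compound 1 gives > 1000 nM, which is a limit and not a number. In this assay compound 2 gives > 1000 nM, also a limit and not a number. For the measured compounds named here, compound 2 therefore has no numerical position, and the series so far shows only (the limit of > 1000 nM in this assay, at which 2 of the 2 values shown sit). Going by the values given here, the only measured step is a step that the two limits leave unreadable from compound 1 to compound 2, so no size can be carried forward.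

Compound 3 `COc1cc2nccc(Oc3ccc4c(Nc5ccccc5)nn(C)c4c3)c2cc1OC` differs from compound 2 as follows: phenyl in place of benzyl on a nitrogen on an aromatic ring. This is phenyl in place of benzyl on a nitrogen on an aromatic ring, or benzylamino to anilino. Among the compounds with values here, no measured step covers this change, and no direction is supported. The expectation rests on compound 2 at > 1000 nM, a limit, so another limit in this assay is the likeliest result. The expected step, with no firm direction, is a step that the limit leaves unreadable from compound 2 to compound 3. For compound 3 the estimated value is 1500 nM, with an expected range from 400 nM to 5000 nM.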

Compound 3, half-maximal inhibitory concentration: > 1000 nM
Compound 3: only a limit was reported (the forecaster's own chance of this, stated with the estimate: 65%); the middle value lies beyond the limit too.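

In this assay compound 3 gives > 1000 nM, a limit and not a number. No step among compound 1, compound 2 and compound 3 can be read, and the series rests on a single limit: the limit of > 1000 nM in this assay, at which 3 of the 3 values shown sit.

The compounds shown leave open how phenyl, benzyl and (3-(trifluoromethyl)phenyl)carbonyl on this nitrogen rank against one another in this assay.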